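Vero cytotoxicity notes: compound 3 to compound 4

The compounds below may be only part of what the source reports. "The series", "measured", "known", "first", "only" and "open" are said of these compounds alone.

The series is followed in an ADME assay on Vero cells (Chlorocebus sabaeus) for cytotoxicity, read by XTT assay, with a stated time of 72 h; on this read-out higher numbers stand for lower toxicity in this test and lower numbers for higher toxicity in this test. Compound 1 `CC1=C(C(=O)Nc2ccccc2Cl)C(c2ccccc2Cl)NC(=S)N1` sits at a limit: in this assay compound 1 gives > 100000 nM, which is a limit and not a number. Compound 2 `CC1=C(C(=O)Oc2ccccc2)C(c2ccccc2)NC(=S)N1` is recorded in this assay as "non-toxic" (no number reported), without any number. Compound 3 `COC(=O)C1=C(C)NC(=S)NC1c1cccs1` likewise stands in this assay at "non-toxic" (no number reported), again with no number attached. Among the measured compounds shown here, compound 3 therefore stands among three entries of which one sits at the limit of > 100000 nM in this assay, at which 1 of the 3 values shown sits, and two carry only a word; no ordering among them can be read, and no compound can be called more or less toxic than another.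

Compound 4 `CCCOC(=O)C1=C(C)NC(=S)NC1c1cccs1` differs from compound 3 by ethyl in place of hydrogen on a saturated chain carbon bound to an oxygen next to a carbonyl group. For the measured compounds named here, no measured step separates the two compounds. Given the three readings, no shift beyond the scatter in this assay is expected from this change, in either direction. Compound 4 is accordingly expected to sit at roughly 100000 nM in this assay, within 30000 nM to 300000 nM, and most likely to be reported only as a limit or as a word rather than as a number.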

Compound 4, half-maximal cytotoxic concentration: 23600 nM
For compound 4 the middle estimate is 4.2-fold (0.63 log units) above the measured one, and the stated range ends above it.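

In this assay, among the compounds shown here, compound 3 stands at "non-toxic" (no number reported) and compound 4 at 23600 nM, so no step between compound 3 and compound 4 can be read. Left open is what shift, if any, the change from methoxycarbonyl to propoxycarbonyl brings to the half-maximal cytotoxic concentration.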